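The source may report more compounds than this note shows. Statements on the series, on what has been measured and on what is new or still open speak of the compounds shown alone.

Compound 1 `CCN[C@H](c1cc(C(F)(F)F)ccc1N1CCN(C(=O)CCc2ccc(Cl)cc2Cl)CC1)C(C)CC` gives 92 nM in an assay on HEK293 cells for displacement of a labelled ligand from Melanocortin receptor 4 (Homo sapiens); a lower number here means a stronger inhibitor, a higher number a weaker inhibitor. Compound 2 `CCC(C)[C@H](NC[C@H](C)N)c1cc(C(F)(F)F)ccc1N1CCN(C(=O)CCc2ccc(Cl)cc2Cl)CC1` gives 89 nM in this assay, and compound 3 `CCC(C)[C@H](NC[C@@H]1CCCN1)c1cc(C(F)(F)F)ccc1N1CCN(C(=O)CCc2ccc(Cl)cc2Cl)CC1` gives 64 nM in this assay. Compound 3 stands at the lower edge of the three numbers, though a 1.4-fold lower number from compound 1 to compound 3 (0.16 log units; within the scatter) and a 1.4-fold lower number from compound 2 to compound 3 (0.14 log units; within the scatter) both fall within the scatter, as does a 1.0-fold lower number from compound 1 to compound 2 (0.01 log units; within the scatter). Compound 4 `CC(C)C[C@H](NC(=O)CN)c1cc(C(F)(F)F)ccc1N1CCN(C(=O)CCc2ccc(Cl)cc2Cl)CC1` differs from compound 3 by 1-(((aminomethyl)carbonyl)amino)-3-methylbutyl in place of 2-methyl-1-(((pyrrolidin-2-yl)methyl)amino)butyl on an aromatic carbon. The three measured steps all vary the substituent on the amine nitrogen and bear on this change only in part; none of them touches the amide or the altered branched chain, so they show only that this position tolerates variation. The expected step in this assay is therefore a 2.3-fold higher number from compound 3 to compound 4 (0.37 log units; beyond the scatter), a modest rise in the number at most. Compound 4 is estimated at 150 nM, with a range of 45 nM to 500 nM.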

Compound 4, inhibition constant: 19 nM
Beside the measured number, compound 4's estimate is 7.9-fold (0.90 log units) above it; the measured number lies below the stated range.
By their numbers in this assay, from the lowest: compound 4; then compounds 3, 2 and 1 (each within the scatter of the next).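

Among the compounds shown here, at this aromatic carbon, 1-(((aminomethyl)carbonyl)amino)-3-methylbutyl gives the first steps beyond the scatter in this assay (a 3.4-fold lower number from compound 3 to compound 4 (0.53 log units; beyond the scatter); a 4.7-fold lower number from compound 2 to compound 4 (0.67 log units; beyond the scatter); a 4.8-fold lower number from compound 1 to compound 4 (0.69 log units; beyond the scatter)). Changes to the amine substituent among compound 1, compound 2 and compound 3 stayed within the scatter, so this position does more than tolerate variation. No measurement shown accounts for the gain.

Going by these compounds, the amide and the 3-methylbutyl chain enter together, so their separate shares remain open. Also open, on these data alone, is whether a hydroxyl or carboxylic acid could replace the amine of the aminomethyl group.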